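The source may report more compounds than this note shows. Statements on the series, on what has been measured and on what is new or still open speak of the compounds shown alone.

Measured in an ADME assay on microsomes from liver (Rattus norvegicus) for metabolic stability, read by LC-MS, with a stated time of 10 min, tested at 0.5 uM; a lower number here means that less of the compound is left, a higher number that more of the compound is left:
compound 1 `c1ccc2c(c1)CN[C@@H](CN(CC[C@@H]1CCCNC1)[C@H]1CCCc3cccnc31)C2`: 28%
compound 2 `c1ccc2c(c1)CN[C@@H](CN(CCC1CCNCC1)[C@H]1CCCc3cccnc31)C2`: 17%
compound 3 `c1ccc2c(c1)CN[C@@H](CN(CCCN1CCN(C3CC3)CC1)[C@H]1CCCc3cccnc31)C2`: 2%

Of these three, compound 3 stands lowest at 2%, and its steps to both others lie beyond the scatter. Compound 4 `c1ccc2c(c1)CN[C@@H](CN(CC[C@H]1CCCNC1)[C@H]1CCCc3cccnc31)C2` differs from it as follows: piperidin-3-yl in place of (4-cyclopropylpiperazin-1-yl)methyl on a saturated chain carbon, two bonds along the chain from an amine nitrogen. That is, piperidin-3-yl comes in place of (4-cyclopropylpiperazin-1-yl)methyl. The closest evidence is a number 26 percentage points lower from compound 1 to compound 3 (beyond the scatter), the same exchange run the other way, although the defined stereocentre of the piperidin-3-yl group is not the same in compound 1 and compound 4. The smaller a number 15 percentage points lower from compound 2 to compound 3 (beyond the scatter) points the same way. A modest rise is therefore expected in this assay, an estimated a number 22 percentage points higher from compound 3 to compound 4 (beyond the scatter). For compound 4 the expected value is 24%, within an estimated range of 10% to 40%.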

Compound 4, percent of the compound remaining: 55%
Compound 4: the middle estimate sits 31 percentage points below what was measured, outside the stated range (above it).
By their numbers in this assay, from the lowest: compound 3; then compound 2; then compound 1; then compound 4.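

The configuration of the piperidin-3-yl group matters in this assay: with atoms and bonds unchanged, there is a number 27 percentage points higher from compound 1 to compound 4 (beyond the scatter). Compound 4 also stands clear of the other side chains, with a number 53 percentage points higher from compound 3 to compound 4 (beyond the scatter) and a number 38 percentage points higher from compound 2 to compound 4 (beyond the scatter), so the size of these exchanges depends on the configuration drawn. The gap within this pair therefore traces to a single feature: the fact that compounds 1 and 4 differ only in the configuration as drawn

Going by these compounds, whether a pyrrolidin-3-yl ring or a longer chain in place of this side chain would keep the higher number stays open. So does the bearing of the other stereo elements on this read-out.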